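A few compounds are considered here, and "the series" means these few. Any claim that something is new, unique, unknown or untested is made for them only; others in the source may bear on it.

Compound 2 `COc1ccc(C[C@@H](O)/C=C/C=C/C(=O)N2CCCCC2)cc1OC` gives 16400 nM in a functional assay on A549 cells (Homo sapiens) for antiproliferative activity, read by sulforhodamine B assay, with a stated time of 48 h (on this read-out lower numbers stand for stronger inhibition and higher numbers for weaker inhibition), the second highest of the three numbers shown. Compound 1 `CCNC(=O)/C=C/C=C/[C@H](O)Cc1ccc(OC)c(OC)c1` gives 13800 nM and compound 3 `COc1ccc(C[C@@H](O)/C=C/C=C/C(=O)N2CCCC2)cc1OC` gives 24400 nM; the steps of a 1.2-fold higher number from compound 1 to compound 2 (0.07 log units; within the scatter) and a 1.5-fold higher number from compound 2 to compound 3 (0.17 log units; within the scatter) both stayed within the scatter, so swapping the group on the carbonyl carbon has so far moved little. Compound 4 `COc1ccc(C[C@@H](O)/C=C/C=C/C(=O)NCc2ccccc2)cc1OC` makes the change (benzylamino in place of piperidin-1-yl on a carbonyl carbon). Since a secondary amine with an ethyl chain, a five-membered ring and a six-membered ring all gave numbers within the scatter of each other, a benzylamino group is expected to do the same. Compound 4 is therefore estimated at 14000 nM, with a range of 6000 nM to 35000 nM, a step of a 1.2-fold lower number from compound 2 to compound 4 (0.07 log units; within the scatter).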

Compound 4, half-maximal inhibitory concentration: 17100 nM
Compound 4: middle estimate off by 1.2-fold (0.09 log units), on the low side; the range from low to high includes it.
By their numbers in this assay, from the lowest: compounds 1, 2, 4 and 3 (each within the scatter of the next).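

In this assay, benzylamino on the carbonyl carbon adds an aromatic ring of carbon only, yet all three new steps lie within the scatter: a 1.0-fold higher number from compound 2 to compound 4 (0.02 log units; within the scatter); a 1.4-fold lower number from compound 3 to compound 4 (0.15 log units; within the scatter); a 1.2-fold higher number from compound 1 to compound 4 (0.09 log units; within the scatter). Across these four compounds, then, neither a six-membered aromatic ring nor a non-aromatic ring separates the numbers. No measurement shown here explains this.

Still open, as far as these compounds go, is whether a carboxylic acid in place of the amide, or a 2-aminoethylamino group on the carbonyl carbon, would give a step beyond the scatter. Changes to the hydroxyl or methoxy groups of the shared core are also open.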